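The source may report more compounds than this note shows. Statements on the series, on what has been measured and on what is new or still open speak of the compounds shown alone.

Within the data shown here, measured compounds so far: compound 1 `CC(=O)Oc1ccc(C(=O)Nc2cc3ccc(OCC4CCCN(C)C4)c(C)c3oc2=O)cc1CC=C(C)C`, 1650 nM; compound 2 `CCN(C)CCCOc1ccc2cc(NC(=O)c3ccc(O)c(CC=C(C)C)c3)c(=O)oc2c1C`, 2190 nM; compound 3 `CC(C)=CCc1cc(C(=O)Nc2cc3ccc(OCCCNCC(=O)O)c(C)c3oc2=O)ccc1O`, 18100 nM.

In a functional assay on MCF7 cells (Homo sapiens) for antiproliferative activity (on this read-out lower numbers stand for stronger inhibition and higher numbers for weaker inhibition), compound 2 has the second highest of these three numbers. Compound 1 sits within the scatter of it, while the gap to compound 3 is an 8.3-fold higher number from compound 2 to compound 3 (0.92 log units; beyond the scatter). Compound 4 `CC(C)=CCc1cc(C(=O)Nc2cc3ccc(OCCCNCCO)c(C)c3oc2=O)ccc1O` has not yet been measured. It differs from compound 2 by one exchange: (2-hydroxyethyl)amino in place of ethyl(methyl)amino on a saturated chain carbon, three bonds along the chain from an oxygen on an aromatic ring. Among the measured compounds shown here, the one measured step that bears on this is the step from compound 2 to compound 3, in which the same ethyl(methyl)amino group was exchanged at the same place and the number rose modestly. For compound 4 a smaller weakening is expected, a 2.1-fold higher number from compound 2 to compound 4 (0.31 log units; beyond the scatter). Compound 4 is therefore estimated at 4500 nM, within a range from 2000 nM to 12000 nM.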

Compound 4, half-maximal inhibitory concentration: 1560 nM
Compound 4: the middle estimate sits 2.9-fold (0.46 log units) above what was measured, and the stated range ends above it.
By their numbers in this assay, from the lowest: compounds 4, 1 and 2 (each within the scatter of the next); then compound 3.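

In this assay, the hydroxyl-bearing amine fits at this place without a measurable penalty: a 1.4-fold lower number from compound 2 to compound 4 (0.15 log units; within the scatter). The earlier weakening therefore tracks with the carboxy group rather than with the loss of ethyl(methyl)amino, since hydroxymethyl in place of carboxy on a saturated chain carbon bound to an amine nitrogen gives a 12-fold lower number from compound 3 to compound 4 (1.06 log units; beyond the scatter). No measurement shown here explains this difference.

As far as these compounds go, whether a primary amine, an amide or a longer chain would fare as well at this place remains open.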